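Chain Extension at the Furan Carbon of a Hydroxamate Series

The source may report more compounds than this note shows. Statements on the series, on what has been measured and on what is new or still open speak of the compounds shown alone.

Measured compounds:
compound 1, `COC(=O)CCCC(=O)N(O)C(C)c1ccc2oc(-c3ccccc3)cc2c1`, 60 nM
compound 2, `CCCCc1cc2cc(C(C)N(O)C(=O)CCCC(=O)OC)ccc2o1`, 50 nM

In an assay on RBL cells for inhibition of Polyunsaturated fatty acid 5-lipoxygenase (Rattus norvegicus) (on this read-out lower numbers stand for stronger inhibition and higher numbers for weaker inhibition), compound 2 gives 50 nM, and compound 1 gives 60 nM; the two numbers are within the scatter of each other, so neither compound can be set apart from the other on this read-out. Within the data shown here, the one measured step, a 1.2-fold lower number from compound 1 to compound 2 (0.08 log units; within the scatter), shows that exchanging the aromatic substituent for a butyl chain left the number unchanged beyond the scatter.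

Compound 3, `CCCCCCCCCCc1cc2cc(C(C)N(O)C(=O)CCCC(=O)OC)ccc2o1`, carries the change (hexyl in place of hydrogen on a saturated chain carbon, four bonds along the chain from an aromatic carbon). Among the measured compounds shown here, no measured step in this assay extends a chain of this kind further, so the only guide is that phenyl and butyl gave the same result. Compound 3 is therefore expected to stay near compound 2, with an estimated step of a 1.6-fold higher number from compound 2 to compound 3 (0.20 log units; within the scatter). The estimate for compound 3 in this assay is 80 nM, with a range from 25 nM to 300 nM.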

Compound 3, half-maximal inhibitory concentration: 150 nM
Compound 3: middle estimate off by 1.9-fold (0.27 log units), on the low side; the range from low to high includes it.
By their numbers in this assay, from the lowest: compounds 2 and 1 (each within the scatter of the next); then compound 3.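

Extending the butyl chain of compound 2 to the decyl chain of compound 3 is the first change in this series to move the number in this assay beyond the scatter (a 3.0-fold higher number from compound 2 to compound 3 (0.48 log units; beyond the scatter)). Decyl also separates from phenyl on the same aromatic carbon (a 2.5-fold higher number from compound 1 to compound 3 (0.40 log units; beyond the scatter)), so the agreement between phenyl and butyl does not extend to every carbon substituent there. The loss is modest, however, and compound 3 still gives 150 nM in this assay. Nothing available accounts for the weaker number with the longer chain. Going by these compounds, it remains open whether the number climbs steadily through hexyl and octyl chains at this carbon or changes abruptly, and whether a longer chain, or a chain ending in a carboxylic acid or an amine, would behave like decyl.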